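The source may hold more compounds than are shown below. What is called first, only, known or untested is meant among the compounds shown, and "the series" means these compounds.

Compound 2 `O=S(=O)(NCCNc1nccc(-c2c(-c3cccc(F)c3)nc3sccn23)n1)c1cccc(F)c1` gives 14900 nM in a functional assay on A-375 cells (Homo sapiens) for cytotoxicity, read by MTT assay (on this read-out higher numbers stand for weaker inhibition and lower numbers for stronger inhibition), the highest of the two numbers recorded so far in the series. Its nearest neighbour, compound 1 `O=S(=O)(NCCCNc1nccc(-c2c(-c3cccc(F)c3)nc3sccn23)n1)c1ccc(Br)cc1`, gives 7040 nM in this assay. Among the compounds with values here, the single measured step, a 2.1-fold higher number from compound 1 to compound 2 (0.33 log units; beyond the scatter), alters both the chain length and the aryl group on the sulfonyl at once, so it does not isolate the change now in question. Compound 3 `O=S(=O)(NCCNc1nccc(-c2c(-c3cccc(F)c3)nc3sccn23)n1)c1ccccc1` differs from compound 2 only by hydrogen in place of fluoro on an aromatic carbon. Within the data shown here, no measured pair shows what removing a fluoro from the phenylsulfonyl ring does here, and the one measured step is itself modest in size. With nothing pointing in either direction, the expected step is a 1.0-fold higher number from compound 2 to compound 3 (0.00 log units; within the scatter), within the usual scatter. Compound 3 is therefore estimated at 15000 nM in this assay, with a likely range of 6000 nM to 40000 nM.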

Compound 3, half-maximal inhibitory concentration: 11000 nM
Compound 3: the middle estimate sits 1.4-fold (0.13 log units) above what was measured; the range from low to high includes it.
By their numbers in this assay, from the lowest: compounds 1, 3 and 2 (each within the scatter of the next, the first and the last beyond it).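

In this assay, within the data shown here, going from 3-fluorophenyl to phenyl on the sulfonyl gives a 1.4-fold lower number from compound 2 to compound 3 (0.13 log units; within the scatter) and so provides the first reading of a change confined to this ring, with no shift beyond the scatter. The wider change in chain and aryl group, read without this fluoro, gives a 1.6-fold higher number from compound 1 to compound 3 (0.19 log units; within the scatter) and stays within the scatter, whereas the same comparison with the fluoro retained was printed as beyond it, so that earlier step offers only thin support for any trend. No supporting data bear on these results.

From the compounds shown here alone, what the chain contributes alone remains open, as both steps from compound 1 alter chain and aryl group together. Also open, going by these compounds, is whether a carboxylic acid or an amine in place of this ring hydrogen would move the number beyond the scatter.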